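A few compounds are considered here, and "the series" means these few. Any claim that something is new, unique, unknown or untested is made for them only; others in the source may bear on it.

In a functional assay (spleen, spleen) for activation, with Mus musculus as the target (a higher number here means that more compound is needed for the effect, a lower number that less compound is needed), compound 2 `Nc1ncnc2c1nc(Cl)n2Cc1ccccc1` gives only a limit of the assay, > 10 uM, not a number. Compound 1 `COc1nc2c(N)ncnc2n1Cc1ccccc1` likewise gives a limit, > 10 uM. The step that the two limits leave unreadable from compound 1 to compound 2 is therefore not readable in size, since both values sit at the same limit (the limit of > 10 uM in this assay, at which 2 of the 2 values shown sit). Compound 3 `CSc1nc2c(N)ncnc2n1Cc1ccccc1` differs from compound 2 by methylsulfanyl in place of chloro on an aromatic carbon. Among the compounds with values here, no measured step offers a readable size, so no change beyond the scatter can be foreseen, and compound 3 is expected to remain near the same limit, the estimated step being a step that the limit leaves unreadable from compound 2 to compound 3. For compound 3 the estimate in this assay is 15 uM, with a range from 4 uM to 60 uM.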

Compound 3, minimum effective concentration: > 10 uM
Compound 3: no number, only a limit; the forecaster's own chance of this, stated with the estimate: 80%; the middle value does not contradict the limit.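

Within the data shown here, no step among compound 1, compound 2 and compound 3 can be read, since all three sit at one limit: the limit of > 10 uM in this assay, at which 3 of the 3 values shown sit. The compounds shown leave open how methoxy, chloro and methylsulfanyl on this aromatic carbon compare in this assay as to the amount of compound needed.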